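Amine swap on the chain of compound 3

The compounds below may be only part of what the source reports. "The series", "measured", "known", "first", "only" and "open" are said of these compounds alone.

Values so far in a functional assay on PC-3 cells (Homo sapiens) for antiproliferative activity, read by MTT assay, with a stated time of 72 h (on this read-out lower numbers stand for stronger inhibition and higher numbers for weaker inhibition), are these:
- compound 1 `O=C(N/N=C/c1cccc(Br)c1)Nc1ccc(Oc2ccnc3[nH]ccc23)c(F)c1` gives 4020 nM
- compound 2 `O=C(N/N=C/c1ccc(F)cc1Cl)Nc1ccc(Oc2ccnc3[nH]ccc23)c(F)c1` gives 3 nM
- compound 3 `CCN(CC)CCn1cccc1/C=N/NC(=O)Nc1ccc(Oc2ccnc3[nH]ccc23)cc1` gives 1370 nM

Compound 3 at 1370 nM holds the middle place of the three numbers, lower than compound 1 and far higher than compound 2. The change to compound 4 `O=C(N/N=C/c1cccn1CCCN1CCCCC1)Nc1ccc(Oc2ccnc3[nH]ccc23)cc1` is (piperidin-1-yl)methyl in place of diethylamino on a saturated chain carbon, two bonds along the chain from an aromatic nitrogen and it sits on a saturated chain carbon, two bonds along the chain from an aromatic nitrogen.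

For the measured compounds named here, the one measured step is a 1300-fold lower number from compound 1 to compound 2 (3.13 log units; beyond the scatter) and it is large, but it is 2-chloro-4-fluorophenyl in place of 3-bromophenyl on a carbon with a double bond to nitrogen, not a change on this chain. Going by the values given here, no measured pair varies the chain, so that step gives no direction here and shows only how far numbers can move.

The estimate is therefore anchored on compound 3 at 1370 nM and no step beyond the scatter is expected in this assay with no firm direction. The expected step is a 1.4-fold lower number from compound 3 to compound 4 (0.14 log units; within the scatter) as a working figure only. For compound 4 the expected value is 1000 nM with an estimated range from 200 nM to 5000 nM kept wide on both sides.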

Compound 4, half-maximal inhibitory concentration: 3580 nM
For compound 4 the middle estimate is 3.6-fold (0.55 log units) below the measured one; low and high end bracket the measured number.
By their numbers in this assay, from the lowest: compound 2; then compound 3; then compounds 4 and 1 (each within the scatter of the next).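

In this assay, the chain on the aromatic nitrogen now has its first measured pair: a 2.6-fold higher number from compound 3 to compound 4 (0.42 log units; beyond the scatter), with 3-(piperidin-1-yl)propyl replacing 2-(diethylamino)ethyl, so this position responds to the change by a modest step beyond the usual scatter. That step is small beside a 1300-fold lower number from compound 1 to compound 2 (3.13 log units; beyond the scatter), a change made elsewhere on the molecule, so within the compounds shown the chain swap moves the number far less than the aryl swap does. The swap alters both the amine and the chain length at once, and no available data separate the two contributions or account for the step.

Still open, as far as these compounds go, is whether 2-(piperidin-1-yl)ethyl, which would keep the chain of compound 3 while carrying the piperidine of compound 4, would sit with compound 3 or with compound 4, and whether a morpholine or a pyrrolidine on the same chain would move the number in the same direction. Also open, from the compounds shown here alone, is whether a step of this size would carry over to the fluorine-bearing core of compound 2.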